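The compounds below may be only part of what the source reports. "The series", "measured", "known", "first", "only" and "open" are said of these compounds alone.

Working notes on the series. Two compounds in this set have been run in a functional assay on K562/Adr cells (Homo sapiens) for inhibition, read by MTT assay, with a stated time of 48 h, tested at 30 uM; a higher number here means more inhibition at the concentration tested (going by the name of the read-out), a lower number less inhibition. Compound 1, `CC(=O)Nc1ccc(-c2cn([C@@H]3CN[C@H](C(=O)Nc4ccc(Cl)c(C(F)(F)F)c4)C3)nn2)cn1`, gives 33.6% in this assay. Compound 2, `CC(C)(C)OC(=O)N1C[C@@H](n2cc(-c3ccc4c(N)n[nH]c4c3)nn2)C[C@H]1C(=O)Nc1ccc(Cl)c(C(F)(F)F)c1`, gives 37.1% in this assay, the higher of the two numbers, though the gap to compound 1 lies within the scatter, so the two read as level. The step under consideration leads from compound 2 to compound 3, `Nc1n[nH]c2cc(-c3cn([C@@H]4CN[C@H](C(=O)Nc5ccc(Cl)c(C(F)(F)F)c5)C4)nn3)ccc12`, where the change is hydrogen in place of tert-butoxycarbonyl on an amine nitrogen in a ring. Among the measured compounds shown here, no measured pair in this set differs only by this change, so there is no measured step to lean on. Because compound 1 gives 33.6% with the same hydrogen at that ring nitrogen, the expected step of a number 4.1 percentage points lower from compound 2 to compound 3 (within the scatter) is small and without clear direction, probably not beyond the scatter. For compound 3 the estimate in this assay is 33%, with a likely range from 16% to 50%.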

Compound 3, a percentage reported as inhibition, at one concentration (the size of the read-out at that concentration, not a potency): 48.2%
Estimate against measurement, compound 3: 15.2 percentage points below; low and high end bracket the measured number.
By their numbers in this assay, from the lowest: compounds 1 and 2 (each within the scatter of the next); then compound 3.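

In this assay, among the compounds shown here, the 3-amino-1H-indazol-6-yl series gives the first measured reading at the amine nitrogen in the ring: a number 11.1 percentage points higher from compound 2 to compound 3 (beyond the scatter) goes with hydrogen in place of tert-butoxycarbonyl, so this position is sensitive to the change. With hydrogen held at that nitrogen, the group on the aromatic carbon also matters, since a number 14.6 percentage points higher from compound 1 to compound 3 (beyond the scatter) goes with 3-amino-1H-indazol-6-yl in place of 6-acetamidopyridin-3-yl. Nothing at hand accounts for either step.

Open, from the compounds shown here alone, is whether a methyl or acetyl group on that ring nitrogen stays with compound 3 or falls towards compound 2, and whether the step from tert-butoxycarbonyl to hydrogen has the same size with 6-acetamidopyridin-3-yl. These readings come from a single concentration, so they leave potency open.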